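Bromine in Place of Benzylsulfanyl on an Inactive Core

The source may report more compounds than this note shows. Statements on the series, on what has been measured and on what is new or still open speak of the compounds shown alone.

Three compounds sharing a core that carries a (2-hydroxy-1-(hydroxymethyl)ethoxy)methyl group were tested in a functional assay on KB cells (Homo sapiens) for inhibition; a higher number here means a weaker inhibitor, a lower number a stronger inhibitor. Compound 1 `OCC(CO)OCn1c(Cl)nc2c(Cl)c(Cl)ccc21` gives > 100000 nM in this assay, which is a limit of the measurement rather than a number. Compound 3 `OCC(CO)OCn1c(S)nc2c(Cl)cc(Cl)cc21` likewise reaches only a limit, > 100000 nM, in this assay. Compound 2 `OCC(CO)OCn1c(SCc2ccccc2)nc2cc(Cl)c(Cl)cc21` stands at the same point: in this assay compound 2 gives > 100000 nM, again a limit and not a number. Among the measured compounds shown here, no measured compound shows a number at all, so no step between measured compounds can be sized; the whole picture is the limit of > 100000 nM in this assay, at which 3 of the 3 values shown sit.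

Compound 4 `OCC(CO)OCn1c(Br)nc2cc(Cl)c(Cl)cc21` differs from compound 2 in one place: bromo in place of benzylsulfanyl on an aromatic carbon. For the measured compounds named here, with every measured value resting at a limit, there is no measured step to lean on. The expected step in this assay is a step that the limit leaves unreadable from compound 2 to compound 4, that is, none beyond the scatter. Compound 4 is therefore estimated at 150000 nM, within a range from 30000 nM to 1000000 nM, and most likely reported once more only as a limit.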

Compound 4, half-maximal inhibitory concentration: > 100000 nM
Compound 4 ended at the assay's limit; the forecaster's own chance of this, stated with the estimate: 85%; the middle value is on the limit's open side.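

Compound 2 and compound 4 both rest at a limit rather than a number, so the step from one to the other cannot be read: the limit of > 100000 nM in this assay, at which 4 of the 4 values shown sit.

The compounds shown leave open whether any change on the shared core would give a measurable value in this assay.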